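This account rests on a few compounds, and the source may have more. Where it says the series, first, only, none or still open, it means among the compounds named here.

Compound 1 `CC(Sc1nc2c(cnn2C)c(=O)n1-c1ccccc1)c1ccccn1` is the starting point of this account. In an assay on isolated protein for inhibition of aldehyde dehydrogenase 1A1 (Homo sapiens) (on this read-out lower numbers stand for stronger inhibition and higher numbers for weaker inhibition), compound 1 gives 242 nM, and this is the highest of the three numbers recorded so far. Compound 2 `CC(Sc1nc2nn(C3COC3)cc2c(=O)n1-c1ccccc1)c1cccnc1` gives 118 nM in this assay, and compound 3 `CC(Sc1nc2nn(C3COC3)cc2c(=O)n1-c1ccccc1)c1ccccc1` gives 109 nM, so both stand at lower numbers than compound 1, each beyond the scatter.

The step under consideration leads to compound 4 `CC(Sc1nc2c(cnn2C)c(=O)n1-c1ccccc1)c1cncnc1`. The change is pyrimidin-5-yl in place of pyridin-2-yl on a saturated chain carbon bound to a saturated chain carbon and a sulfur, a swap of one six-membered aromatic ring for another on the carbon that links the chain to the sulfur.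

Within the data shown here, only one measured step touches the same position: a 1.1-fold lower number from compound 2 to compound 3 (0.03 log units; within the scatter), which exchanges one six-membered aromatic ring for another at that carbon and leaves the number essentially unchanged. Among the measured compounds shown here, that step, however, sits on a different core from that of compound 1, and no measured pair exchanges pyridin-2-yl for pyrimidin-5-yl anywhere in the set. The account therefore expects the ring exchange from compound 1 to compound 4 to give no step beyond the scatter, with a 1.1-fold higher number from compound 1 to compound 4 (0.03 log units; within the scatter) as the estimated outcome.

On this basis compound 4 is expected to give about 260 nM in this assay, within a range from 100 nM to 650 nM.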

Compound 4, half-maximal inhibitory concentration in the aldehyde dehydrogenase 1A1 assay: 94 nM
Compound 4: middle estimate off by 2.8-fold (0.44 log units), on the high side, and the stated range ends above it.
By their numbers in the aldehyde dehydrogenase 1A1 assay, from the lowest: compounds 4, 3 and 2 (each within the scatter of the next); then compound 1.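

Among these compounds, on the core of compound 1, the choice of aromatic ring on this saturated chain carbon does matter: in the aldehyde dehydrogenase 1A1 assay the exchange of pyridin-2-yl for pyrimidin-5-yl gives a 2.6-fold lower number from compound 1 to compound 4 (0.41 log units; beyond the scatter), whereas the only earlier step at this carbon, on another core, was a 1.1-fold lower number from compound 2 to compound 3 (0.03 log units; within the scatter). The earlier compounds shown here therefore gave no sign that a ring exchange here could move the number beyond the scatter, and compound 4 now stands level, within the scatter, with compounds 2 and 3 without carrying their core. In a physicochemical assay for solubility, using the shake flask method, in phosphate buffer, with a stated time of 24 h, at pH 7.4 (on this read-out lower numbers stand for lower solubility and higher numbers for higher solubility), compound 1 gives 20000 nM and compound 4 gives 264000 nM, so the same exchange also comes with higher solubility, and one change improves both read-outs for this pair: the measured solubility of compound 1, 20000 nM, and of compound 4, 264000 nM, a 13-fold higher number (1.12 log units; beyond the scatter)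

The compounds shown leave open whether the pyrimidin-5-yl group gives a step of similar size on the core of compound 2, where the earlier ring exchange left the number within the scatter. They also leave open whether the second ring nitrogen itself matters, and how a pyrazin-2-yl ring or a ring carrying an amine on this carbon would fare in both read-outs.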